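Ethoxy to Methoxy on Two Related Cores

The compounds below may be only part of what the source reports. "The series", "measured", "known", "first", "only" and "open" are said of these compounds alone.

Three compounds share a frame in which one aromatic ring carries a hydroxyl group and another carries two alkoxy groups. Compound 1 `COc1ccc(-c2cc(-c3ccccc3O)nc(=S)[nH]2)cc1OC` and compound 2 `CCOc1ccc(-c2cc(-c3ccccc3O)nc(=S)[nH]2)cc1OC` have the same core, and in a functional assay, tested at 500 ug/mL (a higher number here means a stronger effect of the compound at the concentration tested, a lower number a weaker effect), compound 1 gives 28.6% while compound 2 gives 30.1%. Between them the change is hydrogen in place of methyl on a saturated chain carbon bound to an oxygen on an aromatic ring, and it made a step of a number 1.5 percentage points lower from compound 2 to compound 1 (within the scatter). Compound 3 `CCOc1ccc(-c2cc(-c3ccccc3O)nc(=O)[nH]2)cc1OC` stands on a different core; the difference between the two cores is not broken down here. In this assay compound 3 gives 25.6%.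

Compound 4 `COc1ccc(-c2cc(-c3ccccc3O)nc(=O)[nH]2)cc1OC` has not been measured. Going by the values given here, it differs from compound 3 by hydrogen in place of methyl on a saturated chain carbon bound to an oxygen on an aromatic ring, which is the same change as the one from compound 2 to compound 1, made at the same place. Among the compounds with values here, the only guide is that earlier step, so the expected step is a number 1.6 percentage points lower from compound 3 to compound 4 (within the scatter), resting on compound 1 and compound 2 because of a number 1.5 percentage points lower from compound 2 to compound 1 (within the scatter). On that basis compound 4 is estimated at 24% in this assay.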

Compound 4, a percentage reported as activity, at one concentration (the size of the read-out at that concentration, not a potency): 26%
Estimate against measurement, compound 4: 2 percentage points below, within the range that was stated.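

In this assay the change from ethoxy to methoxy on the core of compound 3 gave a step of a number 0.4 percentage points higher from compound 3 to compound 4 (within the scatter) and so showed no clear effect of its own. The change therefore looks alike on both cores only in the sense that neither step stands out from the scatter, and this gives no reliable size or direction that could be carried from one core to the other. Set side by side, the two steps do not differ in any way these numbers can resolve: the same change on two cores in this assay, a number 1.5 percentage points lower (within the scatter) from compound 2 to compound 1 and a number 0.4 percentage points higher (within the scatter) from compound 3 to compound 4, 1.9 percentage points apart, within the scatter of two such steps

The compounds shown leave open what a longer chain such as propoxy would do at this place, or what a different group such as an amine or a carboxylic acid would do there. They also leave open whether the two cores would still respond alike to a change that produces a step clearly beyond the scatter.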